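The compounds below may be only part of what the source reports. "The series", "measured", "known", "first", "only" and "open" are said of these compounds alone.

In a functional assay on A2780 cells (Homo sapiens) for inhibition (a higher number here means a weaker inhibitor, a lower number a stronger inhibitor), compound 1 `CCCNCc1cc(-c2c(C(=O)NCC)noc2-c2cc(C(C)C)c(O)cc2O)on1` stands as "not determined" (no result reported), while compound 2 `CCNC(=O)c1cc(-c2c(C(=O)NCC)noc2-c2cc(C(C)C)c(O)cc2O)on1` gives 43 nM. Within the data shown here, compound 3 `CCNC(=O)c1noc(-c2cc(C(C)C)c(O)cc2O)c1-c1ccn(C)n1` gives 12 nM, the lowest number so far. Next comes compound 4 `CCNC(=O)c1noc(-c2cc(C(C)C)c(O)cc2O)c1-c1ccn(C(C)C)n1`, which carries isopropyl in place of methyl on an aromatic nitrogen. Among the measured compounds shown here, only one measured step bears on this, and only loosely: a 3.6-fold lower number from compound 2 to compound 3 (0.55 log units; beyond the scatter), where 1-methyl-1H-pyrazol-3-yl replaced 3-(ethylcarbamoyl)-1,2-oxazol-5-yl on an aromatic carbon. For the measured compounds named here, no measured pair alters the group on that nitrogen, so no clear direction can be drawn and no change beyond the scatter is expected in this assay. The expected change is small, a 1.3-fold higher number from compound 3 to compound 4 (0.10 log units; within the scatter). Compound 4 is estimated at 15 nM, with an expected range of 6 nM to 40 nM.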

Compound 4, half-maximal inhibitory concentration: 45 nM
For compound 4 the middle estimate is 3.0-fold (0.48 log units) below the measured one; measured number above the stated range.
By their numbers in this assay, from the lowest: compound 3; then compounds 2 and 4 (each within the scatter of the next).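

In this assay the group on this aromatic nitrogen matters: isopropyl in place of methyl gives a 3.8-fold higher number from compound 3 to compound 4 (0.57 log units; beyond the scatter) and this step lies beyond the scatter. The same change cancels the earlier gain, since a 1.0-fold higher number from compound 2 to compound 4 (0.02 log units; within the scatter) lies within the scatter, so 1-isopropyl-1H-pyrazol-3-yl does not keep the advantage that 1-methyl-1H-pyrazol-3-yl showed over 3-(ethylcarbamoyl)-1,2-oxazol-5-yl. Nothing available explains this loss. The compounds shown leave open how a plain hydrogen, an ethyl or a cyclopropyl on that nitrogen would compare with methyl and isopropyl.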